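The compounds below may be only part of what the source reports. "The series", "measured", "known", "first", "only" and "open" are said of these compounds alone.

Working notes on the series. All compounds share one core carrying a substituted benzylamine. In an assay for inhibition of high affinity nerve growth factor receptor (Homo sapiens), read by HTRF, with a stated time of 30 min, in the presence of a further agent that is not named here (a lower number here means a stronger inhibitor, a higher number a weaker inhibitor), compound 1 `Cc1cc(Nc2nc(NCc3ccc(C#N)cc3)nc3ccccc23)n[nH]1` gives 83 nM. In this assay compound 2 `Cc1cc(Nc2nc(NCc3cc(F)cc(F)c3)nc3ccccc23)n[nH]1` gives 170 nM. Going by the values given here, the one measured step in hand is a 2.0-fold higher number from compound 1 to compound 2 (0.31 log units; beyond the scatter). Among the compounds with values here, compound 2 therefore stands at the higher of the two numbers measured so far, with compound 1 the nearest neighbour.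

Compound 3 `Cc1cc(Nc2nc(NCc3cc(F)c(F)c(F)c3)nc3ccccc23)n[nH]1` differs from compound 2 by fluoro in place of hydrogen on an aromatic carbon. Within the data shown here, no measured step adds a fluoro to a ring that already bears fluoro groups; the only measured step exchanges the whole aryl group for another, and even that step was modest. A single fluoro entering on an aromatic carbon ortho to two fluoro groups and para to a large group is a smaller structural change than that exchange, so a step no larger than the scatter is expected, with the direction left open. For compound 3 the estimate in this assay is 200 nM, within a range of 90 nM to 450 nM. The step this estimate implies is a 1.2-fold higher number from compound 2 to compound 3 (0.07 log units; within the scatter), to be checked once compound 3 is measured.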

Compound 3, half-maximal inhibitory concentration: 870 nM
Compound 3: the middle estimate sits 4.4-fold (0.64 log units) below what was measured, outside the stated range (above it).
By their numbers in this assay, from the lowest: compound 1; then compound 2; then compound 3.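

The added fluoro shows that this position is far from indifferent: a change of one heavy atom gives a larger step (a 5.1-fold higher number from compound 2 to compound 3 (0.71 log units; beyond the scatter)) in this assay than the exchange of the whole aryl group did (a 2.0-fold higher number from compound 1 to compound 2 (0.31 log units; beyond the scatter)). Going by these compounds alone, measured against the 4-cyanophenyl group, the 3,4,5-trifluorophenyl group gives the largest step so far (a 10-fold higher number from compound 1 to compound 3 (1.02 log units; beyond the scatter)), so the choice of benzyl substituent spans a wider range of numbers than the first two compounds suggested. Nothing measured on these compounds accounts for the size of the step from one added fluoro.

From the compounds shown here alone, it remains open whether the higher number belongs to fluoro on an aromatic carbon ortho to two fluoro groups and para to a large group, or to any group at that carbon, since a chloro, methoxy or amine group there would separate these readings. Also open, going by these compounds, is whether the same fluoro would give a step of similar size on a ring without the two other fluoro groups, as a 4-fluorophenyl group would show.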